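Replacing the Sulfonyl Cap with a Pyrrolidine Amide

The source may report more compounds than this note shows. Statements on the series, on what has been measured and on what is new or still open speak of the compounds shown alone.

Compound 1 `O=C(c1ccccn1)N1CCC(NS(=O)(=O)c2cc(S(=O)(=O)c3ccccc3)ccc2C(F)(F)F)CC1` gives 230 nM in an assay on U2OS cells for inhibition of secreted frizzled-related protein 1 (Homo sapiens), read by a luciferase reporter, with a stated time of 18 h; on this read-out lower numbers stand for an effect already at smaller amounts and higher numbers for an effect only at larger amounts of compound.
Compound 2 `O=C(O)c1ccc(S(=O)(=O)N2CCC(NS(=O)(=O)c3cc(S(=O)(=O)c4ccccc4)ccc3C(F)(F)F)CC2)cc1` gives 110 nM in this assay.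

Among the compounds with values here, compound 2 holds the lowest of the two numbers; the only step measured, a 2.1-fold lower number from compound 1 to compound 2 (0.32 log units; beyond the scatter), separates it from compound 1 and is the only one that bears on the change to compound 3 `O=C([C@@H]1CCNC1)N1CCC(NS(=O)(=O)c2cc(S(=O)(=O)c3ccccc3)ccc2C(F)(F)F)CC1`: (pyrrolidin-3-yl)carbonyl in place of (4-carboxyphenyl)sulfonyl on an amine nitrogen in a ring. That step was modest, and compound 3 returns to a carbonyl-linked group like the (pyridin-2-yl)carbonyl of compound 1, so a modest move back toward compound 1 is expected, the step being estimated as a 1.8-fold higher number from compound 2 to compound 3 (0.26 log units; within the scatter). Compound 3 is therefore estimated at 200 nM, within 80 nM to 500 nM.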

Compound 3, half-maximal effective concentration: 380 nM
The estimate for compound 3 lay 1.9-fold (0.28 log units) below the measured number, and the stated range covers the measured number.
By their numbers in this assay, from the lowest: compound 2; then compounds 1 and 3 (each within the scatter of the next).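

In this assay, the amine nitrogen in the ring shows no readable preference between the two carbonyl-linked groups: a 1.7-fold higher number from compound 1 to compound 3 (0.22 log units; within the scatter), with pyrrolidin-3-yl in place of pyridin-2-yl on the carbonyl carbon, and that step lies within the scatter. The (4-carboxyphenyl)sulfonyl group now also stands apart from a second carbonyl-linked group, with a 3.5-fold higher number from compound 2 to compound 3 (0.54 log units; beyond the scatter). Nothing measured here gives a reason for this step.

The compounds shown leave open whether the sulfonyl link or the carboxylic acid carries that difference; a phenylsulfonyl or a (4-carboxyphenyl)carbonyl group on the same nitrogen would separate the two. On these data alone, the opposite configuration at the defined stereocentre of the pyrrolidin-3-yl group also remains open.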